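Selenocyanate linker truncation on the shared core

The compounds below may be only part of what the source reports. "The series", "measured", "known", "first", "only" and "open" are said of these compounds alone.

Measured so far:
compound 1, `COc1ccc(N(C)c2nc(C)nc3ccccc23)cc1OCCCCC[Se]C#N`, 256 nM
compound 2, `COc1ccc(N(C)c2nc(C)nc3ccccc23)cc1C(=O)OCCCC[Se]C#N`, 662 nM

In a functional assay on HCT-116 cells (Homo sapiens) for inhibition, read by MTT assay, with a stated time of 48 h (a higher number here means a weaker inhibitor, a lower number a stronger inhibitor), compound 2 gives the highest of the two numbers; the step of a 2.6-fold higher number from compound 1 to compound 2 (0.41 log units; beyond the scatter) is the only one known. Compound 3, `COc1ccc(N(C)c2nc(C)nc3ccccc23)cc1[Se]C#N`, differs from compound 2 by a group of 3 heavy atoms (1 carbon, 1 nitrogen, 1 selenium; no ring) in place of a group of 10 heavy atoms (6 carbon, 1 nitrogen, 2 oxygen, 1 selenium; no ring), on an aromatic carbon. Going by the values given here, no measured step removes the whole chain, so the one known step gives only a rough guide to size; a modest move in either direction is expected, not clearly beyond the scatter. Compound 3 is therefore estimated at 450 nM, range 120 nM to 1800 nM, meaning an expected step of a 1.5-fold lower number from compound 2 to compound 3 (0.17 log units; within the scatter).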

Compound 3, half-maximal inhibitory concentration: 34 nM
Compound 3: the middle estimate sits 13-fold (1.12 log units) above what was measured; measured number outside the range, below it.
By their numbers in this assay, from the lowest: compound 3; then compound 1; then compound 2.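

At this position, on an aromatic carbon ortho to a methoxy group, removing the chain altogether matters far more than changing it. In this assay, the selenocyanate with no chain gives a 19-fold lower number from compound 2 to compound 3 (1.29 log units; beyond the scatter) and a 7.5-fold lower number from compound 1 to compound 3 (0.88 log units; beyond the scatter), so compound 3 has the lowest number of the three. Nothing available explains this gain.

Still open, as far as these compounds go, is whether a short chain, such as a single methylene between the aromatic carbon and the selenocyanate, keeps this number. A thiocyanate or a plain nitrile in the same place would test whether the selenium is required.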